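Bromo to Chloro at the Same Aromatic Carbon

The source may report more compounds than this note shows. Statements on the series, on what has been measured and on what is new or still open speak of the compounds shown alone.

Measured compounds:
compound 1 `O[C@](Cc1ccccc1Br)(c1ccccc1)[C@@H]1CNCCO1` — 24.1%
compound 2 `COc1ccc(C[C@@](O)(c2ccccc2)[C@@H]2CNCCO2)cc1` — 6.2%

Of the compounds shown here, two have been measured in an assay on isolated protein for displacement of a labelled ligand from sodium-dependent dopamine transporter (Homo sapiens), tested at 1000 nM; on this read-out lower numbers stand for less inhibition and higher numbers for more inhibition at the one concentration tested (going by the name of the read-out). Compound 1 `O[C@](Cc1ccccc1Br)(c1ccccc1)[C@@H]1CNCCO1` gives 24.1% and stands highest of the two; compound 2 `COc1ccc(C[C@@](O)(c2ccccc2)[C@@H]2CNCCO2)cc1` gives 6.2%, a figure that lies below compound 1 by more than the usual scatter. Among the compounds with values here, the two differ in more than one place, so no single step between them can be read off, and the account says only what their two values show.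

Compound 3 `O[C@](Cc1ccccc1Cl)(c1ccccc1)[C@@H]1CNCCO1` has not yet been measured. It differs from compound 1 in one place: chloro in place of bromo on an aromatic carbon. One halogen is exchanged for another on the same aromatic carbon, with no change in ring count, donors, acceptors or charge.

Within the data shown here, with no measured step of this kind among the compounds at hand, the expected step of a number 5.1 percentage points lower from compound 1 to compound 3 (within the scatter) is estimated to be small, leaning slightly downward but possibly none beyond the scatter. Compound 3 is therefore expected to give about 19%, within a range from 7% to 32%.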

Compound 3, a percentage reported as inhibition, at one concentration (the size of the read-out at that concentration, not a potency): 20.8%
Compound 3: middle estimate off by 1.8 percentage points, on the low side; measured number inside the range.
By their numbers in this assay, from the lowest: compound 2; then compounds 3 and 1 (each within the scatter of the next).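

In this assay, within the data shown here, the exchange of 2-bromophenyl for 2-chlorophenyl gives the first step that can be read at a single place, a number 3.3 percentage points lower from compound 1 to compound 3 (within the scatter). It shows that, on this aromatic carbon ortho to a large group, bromo and chloro cannot be told apart on this read-out, something the earlier pair could not show, as those two compounds differ in more than one place. No measurement at hand speaks to the reason for this result.

Going by these compounds, what stays open is whether this carbon accepts only a halogen at this level of inhibition, since a single pair of halogens says nothing about a fluoro, a nitrile or an amine at the same place, or about a phenyl ring with no group there at all. On these data alone, it is also open whether compound 1 and compound 3 would stay inseparable at other concentrations, as each number here is the size of the read-out at one concentration and not a potency.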